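Moving the amine out along the chain in a biphenyl amide series

The compounds below may be only part of what the source reports. "The series", "measured", "known", "first", "only" and "open" are said of these compounds alone.

Measured compounds:
- compound 1 `CC(C)C[C@H](N)CN(C(=O)C(C)Cc1ccccc1)c1ccc(-c2ccccc2)cc1`: a functional assay for agonist activity at G protein-coupled receptor 88 (Homo sapiens), read by HTRF and cAMP accumulation (on this read-out higher numbers stand for an effect only at larger amounts of compound and lower numbers for an effect already at smaller amounts), 1.2 nM
- compound 2 `N[C@H](CN(C(=O)[C@@H]1C[C@H]1c1ccccc1)c1ccc(-c2ccccc2)cc1)C1CCCCC1`: this assay 0.66 nM

Compound 2 gives the lowest number of the two, but the gap to compound 1 sits within the scatter, so no order between them is claimed. Compound 3 `O=C([C@@H]1C[C@H]1c1ccccc1)N(CCNCC1CCCCC1)c1ccc(-c2ccccc2)cc1` differs from compound 2 by ((cyclohexylmethyl)amino)methyl in place of amino(cyclohexyl)methyl on a saturated chain carbon bound to an amide-type nitrogen, so the defined stereocentre of compound 2 is lost. No step between measured compounds is shown that mirrors this change. The step from compound 2 to compound 3 is expected to be a loss well beyond the scatter, a 30-fold higher number from compound 2 to compound 3 (1.48 log units; beyond the scatter). Compound 3 is estimated at 20 nM in this assay, within 2 nM to 200 nM.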

Compound 3, half-maximal effective concentration: 6.6 nM
Compound 3: middle estimate off by 3.0-fold (0.48 log units), on the high side; low and high end bracket the measured number.
By their numbers in this assay, from the lowest: compounds 2 and 1 (each within the scatter of the next); then compound 3.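

In this assay the change from 2-amino-2-cyclohexylethyl to 2-((cyclohexylmethyl)amino)ethyl gives a 10-fold higher number from compound 2 to compound 3 (1.00 log units; beyond the scatter) and shows that this position is sensitive to the change, yet compound 3 still acts without a defined stereocentre. No supporting data accompany this step to explain it.

The loss of the stereocentre and the shift of the amine come together here, so the step cannot be divided between them. Going by these compounds, how a plain 2-aminoethyl group, without the cyclohexane ring, would read at this position stays open.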